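The source may hold more compounds than are shown below. What is called first, only, known or untested is meant among the compounds shown, and "the series" means these compounds.

Measured compounds:
compound 1 `COc1cc(OC)cc(C(=O)NNC(=S)Nc2csc(-c3ccccc3)c2)c1`, 37000 nM in a functional assay on SK-MEL-28 cells (Homo sapiens) for inhibition, read by colorimetric assay and MTT assay, with a stated time of 72 h; on this read-out lower numbers stand for stronger inhibition and higher numbers for weaker inhibition
compound 2 `COc1cc(OC)cc(C(=O)NNC(=S)Nc2csc(-c3ccc(C)cc3)c2)c1`, 38000 nM in this assay
compound 3 `COc1ccc(-c2cc(Nc3nnc(-c4ccc(C)cc4)s3)cs2)cc1`, > 100000 nM in this assay

Compound 3 sits at the limit of this assay (the limit of > 100000 nM in this assay, at which 1 of the 3 values shown sits), so only a limit and no number is known for it. Compound 4 `Cc1ccc(-c2cc(Nc3nnc(-c4ccc(C)cc4)s3)cs2)cc1` differs from compound 3 by one change: methyl in place of methoxy on an aromatic carbon. The only measured step among these compounds is a 1.0-fold higher number from compound 1 to compound 2 (0.01 log units; within the scatter), a different change on a different core, so no measured step covers methoxy to methyl. Nothing here points to movement beyond the scatter in this assay. Compound 4 is therefore expected to stay near the limit, estimated at 100000 nM with a range from 40000 nM to 300000 nM. That estimate means a step of a number no higher from compound 3 to compound 4 (the limit leaves the size open), expected to be within the scatter.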

Compound 4, half-maximal inhibitory concentration: > 100000 nM
Compound 4: only a limit was reported; the forecaster's own chance of this, stated with the estimate: 70%; the middle value sits exactly at the limit.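

Compound 3 and compound 4 each carry only a limit in this assay, so no step can be read between them: the limit of > 100000 nM in this assay, at which 2 of the 4 values shown sit.

The compounds shown leave open whether methyl in place of methoxy changes inhibition at all in this assay.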